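A few compounds are considered here, and "the series" means these few. Any claim that something is new, unique, unknown or untested is made for them only; others in the source may bear on it.

Measured in a functional assay on cells (Cancer cell lines, Homo sapiens) for inhibition; a lower number here means a stronger inhibitor of growth, a higher number a weaker inhibitor of growth:
- compound 1 `Cc1cc(-c2nc3sc(C)cn3c2/C=N/NC(=N)N)c(C)s1`: 8320 nM
- compound 2 `Cc1cn2c(/C=N/NC(=N)N)c(-c3ccsc3)nc2s1`: 6920 nM
- compound 3 `N=C(N)N/N=C/c1c(-c2cccs2)nc2sccn12`: 12000 nM

Compound 3, at 12000 nM, cannot be told apart from compound 1 or compound 2, since all three lie within the usual scatter. Compound 4 `Cc1cn2c(/C=N/NC(=N)N)c(-c3cccs3)nc2s1` differs from compound 3 by methyl in place of hydrogen on an aromatic carbon, with the methyl next to the ring sulfur. For the measured compounds named here, no measured step makes this exact change. Going by the values given here, the closest evidence is the one measured step, thiophen-3-yl in place of 2,5-dimethylthiophen-3-yl, which also concerns methyl groups, though at another place, and gave a 1.2-fold lower number from compound 1 to compound 2 (0.08 log units; within the scatter). Compound 2 already carries the new methyl and shows 6920 nM. The step expected in this assay is therefore a 1.4-fold lower number from compound 3 to compound 4 (0.15 log units; within the scatter), which would stay within the scatter. Compound 4 is estimated at 8500 nM, with an expected range of 4500 nM to 16000 nM.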

Compound 4, concentration for 50% growth inhibition: 4270 nM
Compound 4: the middle estimate sits 2.0-fold (0.30 log units) above what was measured, outside the stated range (below it).
By their numbers in this assay, from the lowest: compounds 4, 2, 1 and 3 (each within the scatter of the next, the first and the last beyond it).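

In this assay, the step of a 2.8-fold lower number from compound 3 to compound 4 (0.45 log units; beyond the scatter) is the only one here beyond the scatter, and it is methyl in place of hydrogen on an aromatic carbon next to the ring sulfur. Changing the thiophene group shows no such separation, with a 1.6-fold lower number from compound 2 to compound 4 (0.21 log units; within the scatter) for thiophen-2-yl in place of thiophen-3-yl and a 1.9-fold lower number from compound 1 to compound 4 (0.29 log units; within the scatter) for thiophen-2-yl in place of 2,5-dimethylthiophen-3-yl.

On these data alone, whether ethyl, chlorine or an amine on this same carbon would shift the number further stays open. No supporting measurement is available to explain the methyl step.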